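Moving the Hydroxyl Around the Phenyl Ring

The source may report more compounds than this note shows. Statements on the series, on what has been measured and on what is new or still open speak of the compounds shown alone.

Two compounds have been measured in an assay on membranes from CHO-K1 cells for displacement of a labelled ligand from 5-hydroxytryptamine receptor 7 (Homo sapiens), read by scintillation counting; a higher number here means a weaker inhibitor, a lower number a stronger inhibitor:

Compound 1, `COc1cc2ncnc(N3CCC(CN4CCN(c5ccccc5O)CC4)C3)c2cc1OC`: 661 nM
Compound 2, `COc1cc2ncnc(N3CCC(CN4CCN(c5cccc(C(F)(F)F)c5)CC4)C3)c2cc1OC`: 229 nM

Within the data shown here, compound 1 has the highest number of the two, so it is the weaker of the pair; its only neighbour is compound 2, reached by a 2.9-fold lower number from compound 1 to compound 2 (0.46 log units; beyond the scatter). Compound 3, `COc1cc2ncnc(N3CCC(CN4CCN(c5ccc(O)cc5)CC4)C3)c2cc1OC`, differs from compound 1 by 4-hydroxyphenyl in place of 2-hydroxyphenyl on an amine nitrogen in a ring. Among the measured compounds shown here, the one measured step, from compound 1 to compound 2, replaces the whole hydroxyphenyl with a trifluoromethylphenyl, a different kind of change, so it bears on the present step only loosely and shows that this position tolerates substantial variation. For the measured compounds named here, no measured pair moves the hydroxyl around the ring. Compound 3 is therefore expected to stay close to compound 1, with a step of a 1.1-fold lower number from compound 1 to compound 3 (0.04 log units; within the scatter) that may well fall within the scatter. The estimate for compound 3 in this assay is 600 nM, with a plausible range from 200 nM to 1800 nM.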

Compound 3, inhibition constant: > 1000 nM
Compound 3 ended at the assay's limit; the forecaster's own chance of this, stated with the estimate: 3%; middle value at least 1.6-fold (0.22 log units) away from the limit.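

Compound 3 gives no exact number in this assay, only a limit of the assay: the limit of > 1000 nM in this assay, at which 1 of the 3 values shown sits.

Turning 2-hydroxyphenyl into 4-hydroxyphenyl, which uses the same atoms joined differently, gives an at least 1.5-fold higher number from compound 1 to compound 3 (0.17 log units; that floor lies within the scatter), so this change brought no gain in binding, but its true size stays unknown and the printed floor does not clear the scatter. The comparison with the 3-(trifluoromethyl)phenyl group is firmer, with an at least 4.3-fold higher number from compound 2 to compound 3 (0.64 log units; beyond the scatter), which shows that the choice of group on this amine nitrogen can move the number beyond the scatter.

From the compounds shown here alone, it remains open how far compound 3 really lies from compound 1. Also open, going by these compounds, is whether 3-hydroxyphenyl, 2-methoxyphenyl or 3-aminophenyl at this place would read closer to compound 1 or to compound 2.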